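Swapping a Halogenated Ring for a Dihydroxyphenyl Ring

The source may report more compounds than this note shows. Statements on the series, on what has been measured and on what is new or still open speak of the compounds shown alone.

Measured in a functional assay on A549 cells (Homo sapiens) for cytotoxicity, read by MTT assay, with a stated time of 72 h; on this read-out higher numbers stand for weaker inhibition and lower numbers for stronger inhibition:
- compound 1, `CN(C)CCn1cnnc1-c1cc(Oc2ccc(NC(=O)N/N=C/c3cccc(Cl)c3Cl)cc2F)ccn1`, gives 1090 nM
- compound 2, `CN(C)CCn1cnnc1-c1cc(Oc2ccc(NC(=O)N/N=C/c3ccc(F)cc3Cl)cc2F)ccn1`, gives 1120 nM

Compound 2 has the highest of the two numbers, but the gap to compound 1 is within the scatter, so the two compounds cannot be told apart on this read-out. Going by the values given here, the one measured step, a 1.0-fold higher number from compound 1 to compound 2 (0.01 log units; within the scatter), exchanged one halogenated ring for another and left the number essentially unchanged.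

Compound 3, `CN(C)CCn1cnnc1-c1cc(Oc2ccc(NC(=O)N/N=C/c3ccc(O)cc3O)cc2F)ccn1`, carries a different change: 2,4-dihydroxyphenyl in place of 2-chloro-4-fluorophenyl on a carbon with a double bond to nitrogen. Here both halogens give way to two hydroxyl groups, a change of a different kind from the measured step, which therefore bears on it only loosely. Among the compounds with values here, with no directly comparable step, compound 3 is expected to land near compound 2, with a wide range: the estimated step is a 1.3-fold higher number from compound 2 to compound 3 (0.13 log units; within the scatter). For compound 3 the estimate in this assay is 1500 nM, from 400 nM to 6000 nM.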

Compound 3, half-maximal inhibitory concentration: 12700 nM
The estimate for compound 3 lay 8.5-fold (0.93 log units) below the measured number, outside the stated range (above it).
By their numbers in this assay, from the lowest: compounds 1 and 2 (each within the scatter of the next); then compound 3.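

In this assay, this position responds strongly to the kind of group it carries, which the swap between two halogenated rings did not reveal. The change to 2,4-dihydroxyphenyl brings an 11-fold higher number from compound 2 to compound 3 (1.05 log units; beyond the scatter), and the same ring in place of 2,3-dichlorophenyl brings a 12-fold higher number from compound 1 to compound 3 (1.07 log units; beyond the scatter), so both large steps point towards weaker inhibition, even though the entering and leaving rings have the same number of heavy atoms. Nothing available explains why the hydroxyl-bearing ring gives this result.

The compounds shown leave open whether a single hydroxyl group would produce a step of this size, as the two hydroxyl groups enter together here. They also leave open how a ring bearing a methoxy group or an amine would compare with the halogenated and dihydroxyphenyl rings.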